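The source may hold more compounds than are shown below. What is called first, only, known or untested is meant among the compounds shown, and "the series" means these compounds.

Compound 1 `COc1ccc(CN2CCC(NC(=O)COc3ccc4c(=O)c(-c5ccccc5)coc4c3)CC2)cc1` in a functional assay on HepG2 cells (Homo sapiens) for cytotoxicity, read by MTT assay, with a stated time of 72 h (on this read-out higher numbers stand for weaker inhibition and lower numbers for stronger inhibition), is reported only as a limit, > 20000 nM. Compound 2 `N#Cc1ccc(CN2CCC(NC(=O)COc3ccc4c(=O)cc(-c5ccccc5)oc4c3)CC2)cc1` gives 9300 nM. Compound 3 `COc1ccc(CN2CCC(NC(=O)C(C)(C)Oc3ccc4c(=O)cc(-c5ccccc5)oc4c3)CC2)cc1` gives 8700 nM.

Compound 3 and compound 2 sit within the scatter of each other, so neither can be placed ahead of the other. The value of compound 1 is a limit of > 20000 nM in this assay, at which 1 of the 3 values shown sits, and not a number. From compound 3 the path leads to compound 4 `CC(C)(Oc1ccc2c(=O)cc(-c3ccccc3)oc2c1)C(=O)NC1CCN(Cc2ccccc2)CC1` through (hydrogen in place of methoxy on an aromatic carbon), hydrogen in place of methoxy on an aromatic carbon. Within the data shown here, no measured pair shows this change, so nothing here points to a shift beyond the scatter in this assay. The step of a 1.4-fold higher number from compound 3 to compound 4 (0.14 log units; within the scatter) is therefore expected to be small. Compound 4 is estimated at 12000 nM, with a range from 5000 nM to 30000 nM.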

Compound 4, half-maximal inhibitory concentration: 14000 nM
The estimate for compound 4 lay 1.2-fold (0.07 log units) below the measured number; measured number inside the range.
By their numbers in this assay, from the lowest: compounds 3, 2 and 4 (each within the scatter of the next). At a limit, above all of these: compound 1.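

In this assay, among these compounds, the change from 4-methoxybenzyl to benzyl gives the first comparison of compounds that differ in one place, a 1.6-fold higher number from compound 3 to compound 4 (0.21 log units; within the scatter). The methoxy group on this aromatic carbon can thus give way to hydrogen without a shift beyond the scatter. Nothing measured here gives a reason for this step.

As far as these compounds go, whether a hydroxyl group or an amine at this place would move the number beyond the scatter stays open. It is also open whether the same change would read alike in the other compounds shown.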